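The source may report more compounds than this note shows. Statements on the series, on what has been measured and on what is new or still open speak of the compounds shown alone.

In a functional assay on MCF7 cells (Homo sapiens) for antiproliferative activity, read by MTT assay, with a stated time of 48 h (on this read-out higher numbers stand for weaker inhibition and lower numbers for stronger inhibition), compound 1 `O=[N+]([O-])c1cc(C(F)(F)F)cc([N+](=O)[O-])c1Oc1ccccc1/C=N/OCc1ccccc1Cl` gives 1100 nM and compound 2 `O=[N+]([O-])c1cc(C(F)(F)F)cc([N+](=O)[O-])c1Oc1ccc(Br)cc1/C=N\OCc1ccccc1F` gives 1120 nM, so compound 2 stands level with compound 1, within the scatter. Compound 3 `O=[N+]([O-])c1cc(C(F)(F)F)cc([N+](=O)[O-])c1Oc1ccc(Br)cc1/C=N/OCc1ccccc1Cl` differs from compound 2 by a group of 11 heavy atoms (8 carbon, 1 nitrogen, 1 oxygen, 1 chlorine; one six-membered aromatic ring of carbon only) in place of a group of 11 heavy atoms (8 carbon, 1 nitrogen, 1 oxygen, 1 fluorine; one six-membered aromatic ring of carbon only), on an aromatic carbon. Going by the values given here, no measured step isolates this change, and the data offer no direction for it. Among the compounds with values here, the only guide is compound 2 at 1120 nM, so no shift beyond the scatter is expected in this assay. The expected size is a 1.0-fold lower number from compound 2 to compound 3 (0.01 log units; within the scatter). For compound 3, the estimated value is 1100 nM, with an expected range of 550 nM to 2200 nM.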

Compound 3, half-maximal inhibitory concentration: 2840 nM
Estimate against measurement, compound 3: 2.6-fold (0.41 log units) below, and the stated range ends below it.
By their numbers in this assay, from the lowest: compounds 1 and 2 (each within the scatter of the next); then compound 3.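

In this assay this position responds beyond the scatter: a 2.6-fold higher number from compound 1 to compound 3 (0.41 log units; beyond the scatter) with bromo in place of hydrogen on an aromatic carbon, and a 2.5-fold higher number from compound 2 to compound 3 (0.40 log units; beyond the scatter) with the chlorine-bearing group in place of the fluorine-bearing group. That second change also reverses the geometry at the double bond outside aromatic rings, so the halogen and the geometry cannot be separated. Nothing available accounts for either step.

Open, going by these compounds, is whether a methoxy group in place of bromo would give a similar step. Also open, on these data alone, is how the two geometries compare when both carry the same halogen.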